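From Compound 2 to Compound 4 in a Growth Assay

A few compounds are considered here, and "the series" means these few. Any claim that something is new, unique, unknown or untested is made for them only; others in the source may bear on it.

Compound 1 `CC1=CC[C@@H]([C@@](C)(O)CCCC(C)(C)NC=S)CC1` gives 9250 nM in a functional assay on NCI-H460 cells (Homo sapiens) for cytotoxicity, read by sulforhodamine B assay; a lower number here means a stronger inhibitor of growth, a higher number a weaker inhibitor of growth. Compound 2 `CC1=CC[C@@H]([C@@](C)(O)CCCC(C)(C)NC(=S)N/N=C\c2ccccc2)CC1` gives 38400 nM in this assay, the highest number of the three; the step of a 4.2-fold higher number from compound 1 to compound 2 (0.62 log units; beyond the scatter) lies beyond the scatter, whereas compound 3 `CC1=CC[C@@H]([C@@](C)(O)CCCC(C)(C)NC(=S)N/N=C\c2ccc(N(C)C)cc2)CC1`, with 19600 nM, sits within the scatter of compound 2, as the step of a 2.0-fold lower number from compound 2 to compound 3 (0.29 log units; within the scatter) shows. Compound 4 `CC1=CC[C@@H]([C@@](C)(O)CCCC(C)(C)NC(=S)N/N=C(/C)c2ccccc2)CC1` differs from compound 2 by a group of 9 heavy atoms (8 carbon, 1 nitrogen; one six-membered aromatic ring of carbon only) in place of a group of 8 heavy atoms (7 carbon, 1 nitrogen; one six-membered aromatic ring of carbon only), on an amide-type nitrogen. Neither measured step touches this part of the molecule: one adds the whole arm, the other alters the aromatic ring. Going by the values given here, with no comparable step, a change within the scatter is the plainest expectation, so compound 4 is estimated at 38000 nM (range 15000 nM to 100000 nM), a step of a 1.0-fold lower number from compound 2 to compound 4 (0.00 log units; within the scatter) expected to stay within the scatter.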

Compound 4, concentration for 50% growth inhibition: 12600 nM
Beside the measured number, compound 4's estimate is 3.0-fold (0.48 log units) above it; the whole stated range lies above it.
By their numbers in this assay, from the lowest: compounds 1, 4, 3 and 2 (each within the scatter of the next, the first and the last beyond it).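

This part of the arm is not silent: on the amide-type nitrogen, the group of 9 heavy atoms in place of the group of 8 gives a 3.0-fold lower number from compound 2 to compound 4 (0.48 log units; beyond the scatter) in this assay. A small change here therefore moves the number beyond the scatter, whereas dimethylamino on the aromatic ring gave only a 2.0-fold lower number from compound 2 to compound 3 (0.29 log units; within the scatter). Nothing available explains the shift. As far as these compounds go, whether a longer chain such as propyl, or a cyclopropyl ring, at this place would lower the number further remains open. So does whether dimethylamino on the aromatic ring of compound 4 would change it.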